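Aryl exchange on the amine nitrogen of compound 3

This account rests on a few compounds, and the source may have more. Where it says the series, first, only, none or still open, it means among the compounds named here.

Compound 1, `CCCCCCCCNc1nc(SCc2ccc(C(F)(F)F)cc2)nc2ccccc12`, gives 10500 nM in a functional assay on PC-3 cells (Homo sapiens) for cytotoxicity, read by MTT assay, with a stated time of 72 h; a higher number here means a weaker inhibitor, a lower number a stronger inhibitor.
Compound 2, `FC(F)(F)c1ccc(CSc2nc(N3CCCCC3)c3ccccc3n2)cc1`, gives 25500 nM in this assay.
Compound 3, `COc1ccccc1Nc1nc(SCc2ccc(C(F)(F)F)cc2)nc2ccccc12`, gives 14100 nM in this assay.

Compound 3 holds the second highest of the three numbers. Its nearest neighbour is compound 1, and the step of a 1.3-fold higher number from compound 1 to compound 3 (0.13 log units; within the scatter) lies within the scatter; the step of a 1.8-fold lower number from compound 2 to compound 3 (0.26 log units; within the scatter) also stays within it. Within the data shown here, only the step of a 2.4-fold higher number from compound 1 to compound 2 (0.39 log units; beyond the scatter) goes beyond the scatter, and it is modest.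

Compound 4, `FC(F)(F)c1ccc(CSc2nc(Nc3cccc(C(F)(F)F)c3)c3ccccc3n2)cc1`, differs from compound 3 in one place: 3-(trifluoromethyl)phenyl in place of 2-methoxyphenyl on a nitrogen on an aromatic ring. The two measured steps that touch this position, the exchange of octyl for 2-methoxyphenyl and of piperidin-1-yl for (2-methoxyphenyl)amino, were both within the scatter, yet neither exchanges one aryl group for another, so they offer only weak guidance. Since the substituent on this nitrogen has so far moved the number little, compound 4 is expected to stay close to compound 3, with the step of a 1.0-fold lower number from compound 3 to compound 4 (0.00 log units; within the scatter) expected to fall within the scatter. The estimate for compound 4 in this assay is 14000 nM, with a range of 5000 nM to 40000 nM.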

Compound 4, half-maximal inhibitory concentration: 12900 nM
The estimate for compound 4 lay 1.1-fold (0.04 log units) above the measured number; measured number inside the range.
By their numbers in this assay, from the lowest: compounds 1, 4, 3 and 2 (each within the scatter of the next, the first and the last beyond it).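

In this assay, among these compounds, this is the first exchange of one aryl group for another on the amine nitrogen, and a 1.1-fold lower number from compound 3 to compound 4 (0.04 log units; within the scatter) shows that 3-(trifluoromethyl)phenyl replaces 2-methoxyphenyl with no change beyond the scatter, even though the hydrogen-bond acceptor of the leaving group is lost. Compound 4 also stays within the scatter of both non-aryl comparators, with a 1.2-fold higher number from compound 1 to compound 4 (0.09 log units; within the scatter) for the exchange of octyl and a 2.0-fold lower number from compound 2 to compound 4 (0.30 log units; within the scatter) for the exchange of piperidin-1-yl, although a 2.4-fold higher number from compound 1 to compound 2 (0.39 log units; beyond the scatter) lies beyond it. Nothing measured here accounts for how closely these numbers sit.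

As far as these compounds go, whether an aryl group carrying a carboxylic acid or a dimethylamino group on this nitrogen would behave the same remains open. So does whether a short chain such as ethyl would hold the number within the scatter of compound 1.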